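Substituent at the aromatic carbon between two ring nitrogens

The compounds below may be only part of what the source reports. "The series", "measured", "known", "first", "only" and "open" are said of these compounds alone.

Three compounds share one core. Compound 1 `CCCSc1nc(N)c2nc(O)n(Cc3ccccc3)c2n1` carries propylsulfanyl at the aromatic carbon between the two ring nitrogens, compound 2 `CCCCc1nc(N)c2nc(O)n(Cc3ccccc3)c2n1` carries butyl there, and compound 3 `Nc1ncnc2c1nc(O)n2Cc1ccccc1` carries only hydrogen. In a functional assay (spleen, spleen) for activation, with Mus musculus as the target (on this read-out lower numbers stand for an effect already at smaller amounts and higher numbers for an effect only at larger amounts of compound), compound 1 gives 0.01 uM, compound 2 gives 0.03 uM and compound 3 gives 10 uM. Compound 3 therefore stands at the highest of the three numbers in this assay; its nearest neighbour is compound 2, and the change is a 330-fold higher number from compound 2 to compound 3 (2.52 log units; beyond the scatter), while compound 1 lies further away, with a 1000-fold higher number from compound 1 to compound 3 (3.00 log units; beyond the scatter). Between the two substituted compounds the step is a 3.0-fold higher number from compound 1 to compound 2 (0.48 log units; beyond the scatter).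

Compound 4 `CCNc1nc(N)c2nc(O)n(Cc3ccccc3)c2n1` is not yet measured. Its change from compound 3 is ethylamino in place of hydrogen on an aromatic carbon. Both measured steps into compound 3 bear on this: removing propylsulfanyl or butyl from that carbon raised the number by a large amount, so adding ethylamino at the same carbon is expected to lower it substantially. Ethylamino is a different group and shorter than either chain, so the full size of those steps is not assumed. Compound 4 is expected to give 0.1 uM in this assay, with a range of 0.01 uM to 1 uM, which corresponds to an expected step of a 100-fold lower number from compound 3 to compound 4 (2.00 log units; beyond the scatter).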

Compound 4, minimum effective concentration: 1 uM
Beside the measured number, compound 4's estimate is 10-fold (1.00 log units) below it, within the range that was stated.
By their numbers in this assay, from the lowest: compound 1; then compound 2; then compound 4; then compound 3.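

Notes on the series: in this assay the gain is a 10-fold lower number from compound 3 to compound 4 (1.00 log units; beyond the scatter) and so ethylamino at this carbon, between two ring nitrogen atoms, is clearly better than hydrogen, but only part of the gain seen with the two earlier substituents is recovered. The remaining gaps are a 33-fold higher number from compound 2 to compound 4 (1.52 log units; beyond the scatter) and a 100-fold higher number from compound 1 to compound 4 (2.00 log units; beyond the scatter) and both are wider than the earlier step of a 3.0-fold higher number from compound 1 to compound 2 (0.48 log units; beyond the scatter) so this position separates substituents from one another, not merely substituted compounds from the unsubstituted compound 3. No measurement available here accounts for the position of ethylamino in this order.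

Ethylamino differs from butyl and propylsulfanyl in both its chain and the atom joining it to the ring, so these compounds cannot show which of the two matters. Butylamino or propylamino would test the nitrogen link at a longer chain length, while ethylsulfanyl or propyl would test the shorter chain with a sulfur or carbon link, and a dialkylamino group such as dimethylamino would show whether the amine hydrogen matters.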